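Dropping the Methoxy: An Expectation for Compound 4

This account rests on a few compounds, and the source may have more. Where it says the series, first, only, none or still open, it means among the compounds named here.

Of the compounds shown here, three built on one shared core have been tested in a functional assay on MGC-803 cells (Homo sapiens) for antiproliferative activity, read by CCK-8 assay, with a stated time of 72 h; on this read-out lower numbers stand for stronger inhibition and higher numbers for weaker inhibition. Compound 1 `O=C(Nc1ccc(-c2cnc3ccccn23)cc1)c1ccc([N+](=O)[O-])o1` gives 590 nM. Compound 2 `COc1ccn2c(-c3ccc(NC(=O)c4ccc([N+](=O)[O-])o4)cc3F)cnc2c1` gives 1080 nM. Compound 3 `COc1ccn2c(-c3ccc(NC(=O)c4ccc([N+](=O)[O-])o4)cc3C)cnc2c1` gives 1030 nM; this number stands second highest of the three, indistinguishable from compound 2 and within the usual scatter of compound 1, so none of the three can be called stronger or weaker than another.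

Compound 4 `Cc1cc(NC(=O)c2ccc([N+](=O)[O-])o2)ccc1-c1cnc2ccccn12` differs from compound 3 in a single place: hydrogen in place of methoxy on an aromatic carbon. For the measured compounds named here, no measured step removes a methoxy on its own, so this change has no direct precedent. Going by the values given here, the one measured step, a 1.0-fold lower number from compound 2 to compound 3 (0.02 log units; within the scatter), shows that swapping a small group elsewhere on the molecule left the number where it was. Compound 1 and compound 3, which differ in two places, also sit within the scatter of each other. The change is therefore expected to be small: a 1.4-fold lower number from compound 3 to compound 4 (0.14 log units; within the scatter). Compound 4 is expected to give 750 nM, with a range from 350 nM to 1600 nM.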

Compound 4, half-maximal inhibitory concentration: 900 nM
Compound 4: middle estimate off by 1.2-fold (0.08 log units), on the low side; the range from low to high includes it.
By their numbers in this assay, from the lowest: compounds 1, 4, 3 and 2 (each within the scatter of the next).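

In this assay, taking the methoxy off the six-membered aromatic ring with 1 nitrogen now has a measured step of its own (a 1.1-fold lower number from compound 3 to compound 4 (0.06 log units; within the scatter)), so methoxy and hydrogen at this position cannot be told apart. For the compounds shown here, compound 4 also gives the first single-place reading of an added methyl (a 1.5-fold higher number from compound 1 to compound 4 (0.18 log units; within the scatter)), and that swap cannot be told from no change either. Nothing measured here explains why these numbers stay within the scatter of each other.

The compounds shown hold only methoxy and hydrogen at this position, so they leave open whether an amine, a carboxylic acid or a longer chain such as butoxy would move the number. They also leave open whether any other group on the aromatic carbon that now carries methyl would give a step beyond the scatter.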